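Amide variation on a pyrrolidinyl-pyrrolidine histamine scaffold

The source may hold more compounds than are shown below. What is called first, only, known or untested is meant among the compounds shown, and "the series" means these compounds.

Measured so far:
compound 1, `Cc1cc(NC(=O)C2C(C)(C)C2(C)C)ccc1N1CCC(N2CCCC2C)C1`, 65.5 nM
compound 2, `Cc1cc(N2CC[C@H](N3CCC[C@@H]3C)C2)ccc1NC(=O)C1CC2CCC1C2`, 0.55 nM

The two measured compounds share a core and differ in the amide part. In an assay on CHO cells for displacement of a labelled ligand from histamine receptor H3 (Macaca mulatta) (a higher number here means a weaker inhibitor, a lower number a stronger inhibitor), compound 1 gives 65.5 nM, which is the higher of the two numbers; compound 2, with its bicyclic amide and defined stereocentres, gives 0.55 nM in this assay, and the gap between the two lies well beyond the usual scatter. Within the data shown here, no step between measured compounds that differ in a single place is available, so the size of any amide change has not been calibrated directly.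

Compound 3, `Cc1cc(NC(=O)C2CCCO2)ccc1N1CCC(N2CCCC2C)C1`, follows from compound 1 by one change: oxolan-2-yl in place of 2,2,3,3-tetramethylcyclopropyl on a carbonyl carbon. The remainder of the molecule, including the undefined stereocentres of compound 1, is kept. With only the distant comparison to compound 2 at hand, the step of a 1.8-fold higher number from compound 1 to compound 3 (0.26 log units; within the scatter) is expected to be modest in this assay, if anything toward a weaker inhibitor. Compound 3 is therefore estimated at 120 nM in this assay, within a range of 20 nM to 700 nM.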

Compound 3, inhibition constant: 17 nM
Compound 3: middle estimate off by 7.1-fold (0.85 log units), on the high side; the whole stated range lies above it.
By their numbers in this assay, from the lowest: compound 2; then compound 3; then compound 1.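

Among these compounds, replacing 2,2,3,3-tetramethylcyclopropyl with oxolan-2-yl on a carbonyl carbon gives, in this assay, a 3.9-fold lower number from compound 1 to compound 3 (0.59 log units; beyond the scatter), and this is the first direct measure of a change at this place. It shows that the group on the carbonyl carbon can alter the result on its own, and that the all-carbon 2,2,3,3-tetramethylcyclopropyl group is not needed to keep binding in this assay, since the oxolan-2-yl ring, with one oxygen and one hydrogen-bond acceptor, gives the stronger inhibitor of this pair. Nothing available accounts for the direction or the size of this step.

The compounds shown leave open whether the ring oxygen matters at all or whether the loss of the 2,2,3,3-tetramethylcyclopropyl carbon framework is enough, a question that a cyclopentyl group, which has the ring size of oxolan-2-yl but no oxygen, would address directly. Also open, going by these compounds, is how far the result extends to a six-membered oxan-2-yl ring or to an open methoxymethyl chain, and whether the step keeps its size on a single defined stereoisomer of the shared core.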